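Swapping Tert-Butyl for (Tert-Butoxycarbonyl)methyl on the Ring Amine

The source may hold more compounds than are shown below. What is called first, only, known or untested is meant among the compounds shown, and "the series" means these compounds.

Of the compounds shown here, two built on one shared core have been measured in a functional assay (strain AB) with Danio rerio as the target, read by microscopy, with a stated time of 1 h; on this read-out lower numbers stand for an effect already at smaller amounts and higher numbers for an effect only at larger amounts of compound. Compound 1, `CC(C)(C)CN1CCc2c(sc(NC(=O)Nc3ccc(Cl)cc3)c2C(N)=O)C1`, gives 5560 nM in this assay. Compound 2, `CCN1CCc2c(sc(NC(=O)Nc3ccc(Cl)cc3)c2C(=O)NCCO)C1`, gives 9400 nM in this assay; the gap between these two values lies within the usual scatter, so neither can be called the stronger. Compound 3, `CC(C)(C)OC(=O)CCN1CCc2c(sc(NC(=O)Nc3ccc(Cl)cc3)c2C(N)=O)C1`, has not yet been measured. It differs from compound 1 in one place: (tert-butoxycarbonyl)methyl in place of tert-butyl on a saturated chain carbon bound to an amine nitrogen in a ring. Within the data shown here, no measured pair shows what this exchange does on its own, and compound 2 differs from compound 1 in more than one place, so it gives no direct guide. With both measured values close together and the change confined to the group on the ring amine, only a small step is expected, a 1.3-fold higher number from compound 1 to compound 3 (0.10 log units; within the scatter), with no clear direction beyond the scatter. Compound 3 is therefore estimated at 7000 nM, within a range from 2500 nM to 20000 nM.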

Compound 3, half-maximal effective concentration: 1100 nM
Estimate against measurement, compound 3: 6.4-fold (0.80 log units) above; the whole stated range lies above it.
By their numbers in this assay, from the lowest: compound 3; then compounds 1 and 2 (each within the scatter of the next).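

In this assay the exchange of tert-butyl for (tert-butoxycarbonyl)methyl on the ring amine gives a 5.1-fold lower number from compound 1 to compound 3 (0.70 log units; beyond the scatter) and so shows that this position responds to what is attached there. The entering group is the larger one, with 8 heavy atoms against 4 and with 2 hydrogen-bond acceptors against 0, yet the number falls rather than rises, something the pair of compound 1 and compound 2 could not show. Nothing measured here says why the number falls.

The exchange alters chain length, carbonyl and tert-butyl ester all at once, so the compounds shown do not tell which of these parts carries the step. A plain longer alkyl chain without the carbonyl, or a carboxylic acid in place of the ester, would pull these parts apart.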